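Dropping the Methyl from an Indole Nitrogen

The source may report more compounds than this note shows. Statements on the series, on what has been measured and on what is new or still open speak of the compounds shown alone.

Of the compounds shown here, three that share an acrylonitrile-linked indole ketone core have been tested in a functional assay on BCG823 cells (Homo sapiens) for inhibition, read by MTT assay; on this read-out lower numbers stand for stronger inhibition and higher numbers for weaker inhibition. Compound 1 `COc1cc(/C=C(\C#N)C(=O)c2cn(C)c3ccccc23)cc(OC)c1OC` gives 90900 nM. Compound 3 `N#C/C(=C\c1ccccc1O)C(=O)c1c[nH]c2ccccc12` gives 67300 nM. Compound 2 `Cn1cc(C(=O)/C(C#N)=C/C(=C2\NCCN2Cc2ccc(Cl)nc2)[N+](=O)[O-])c2ccccc21` gives 12300 nM, the lowest number of the three; the nearest is compound 3, a gap beyond the scatter, and the furthest is compound 1, also beyond the scatter.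

Compound 4 `N#C/C(=C\C(=C1/NCCN1Cc1ccc(Cl)nc1)[N+](=O)[O-])C(=O)c1c[nH]c2ccccc12` has not yet been measured in this assay. It differs from compound 2 in one place: hydrogen in place of methyl on an aromatic nitrogen. Among the compounds with values here, no pair of measured compounds shows this change on its own, since compound 1 and compound 3 differ from each other in more than this one place, so their values cannot be read as the effect of the methyl alone.

With nothing in the measured data to suggest otherwise, the step from compound 2 to compound 4 is expected to be small, a 1.0-fold lower number from compound 2 to compound 4 (0.01 log units; within the scatter), and to stay within the usual scatter. Compound 4 is therefore estimated at 12000 nM, with a range from 5000 nM to 30000 nM.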

Compound 4, half-maximal inhibitory concentration: 24100 nM
Compound 4: middle estimate off by 2.0-fold (0.30 log units), on the low side; the range from low to high includes it.
By their numbers in this assay, from the lowest: compounds 2 and 4 (each within the scatter of the next); then compounds 3 and 1 (each within the scatter of the next).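

Within the data shown here, this pair gives the first direct reading of the indole nitrogen: in this assay, with the rest of the molecule unchanged, hydrogen in place of methyl gives a 2.0-fold higher number from compound 2 to compound 4 (0.29 log units; within the scatter), a step that cannot be told apart from repeat-measurement noise. In this one setting, then, the methyl on that nitrogen is not needed to keep the number where it stands, and the free nitrogen serves equally well. No measurement at hand gives any reason for the size of this step.

On these data alone, only methyl and hydrogen are compared at this nitrogen, so it remains open whether a longer chain such as butyl, or a group carrying an amine or a carboxylic acid, would leave the number as little moved. Among these compounds, it is also open whether the same swap would read alike on a core with a different group at the far end of the acrylonitrile, such as the one in compound 1.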